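Adding a ring hydroxy to a dopamine transporter ligand

A few compounds are considered here, and "the series" means these few. Any claim that something is new, unique, unknown or untested is made for them only; others in the source may bear on it.

Measured compounds in an assay on striatum for inhibition of sodium-dependent dopamine transporter (Rattus norvegicus); a lower number here means a stronger inhibitor, a higher number a weaker inhibitor:
Compound 1, `COc1ccc(CN[C@@H]2CO[C@H](C(c3ccccc3)c3ccccc3)C[C@H]2O)cn1`, gives 44.1 nM.
Compound 2, `COc1cc(CN[C@@H]2CO[C@H](C(c3ccccc3)c3ccccc3)C[C@H]2O)ccc1O`, gives 167 nM.
Compound 3, `c1ccc(C(c2ccccc2)[C@@H]2CC[C@H](NCc3ccc4occc4c3)CO2)cc1`, gives 81.9 nM.

Compound 3 sits in the middle of these three numbers. Against compound 1 the gap is within the usual scatter, so no order between the two can be claimed. Compound 2 gives a higher number than compound 3, a gap beyond the scatter, so compound 3 is the stronger inhibitor of that pair.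

Compound 4, `O[C@@H]1C[C@@H](C(c2ccccc2)c2ccccc2)OC[C@H]1NCc1ccc2occc2c1`, differs from compound 3 in one place: hydroxy in place of hydrogen on a saturated ring carbon. Compound 4 thus carries the same ring hydroxy that compounds 1 and 2 have, while keeping the benzofuran arm of compound 3.

For the measured compounds named here, the only measured step, a 3.8-fold higher number from compound 1 to compound 2 (0.58 log units; beyond the scatter), swaps the aromatic arm and leaves the ring hydroxy untouched; it says nothing about adding or removing that hydroxy. Going by the values given here, no measured pair isolates the change from compound 3 to compound 4, so the expectation rests on the change being small in atom count and on compounds 1 and 2, both hydroxy-bearing, sitting in the same general range as compound 3.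

The step from compound 3 to compound 4 is therefore expected to be a 1.4-fold lower number from compound 3 to compound 4 (0.14 log units; within the scatter), at most a modest shift in either direction. Compound 4 is estimated at 60 nM, with a range from 20 nM to 180 nM.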

Compound 4, inhibition constant: 234 nM
Compound 4: middle estimate off by 3.9-fold (0.59 log units), on the low side; measured number above the stated range.
By their numbers in this assay, from the lowest: compounds 1 and 3 (each within the scatter of the next); then compounds 2 and 4 (each within the scatter of the next).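

In this assay, for the compounds shown here, hydroxy in place of hydrogen on this saturated ring carbon, three ring bonds from the ring oxygen, gives a 2.9-fold higher number from compound 3 to compound 4 (0.46 log units; beyond the scatter) and so weakens inhibition beyond the scatter, the first direct reading of this change at this position. With the hydroxy present, the aromatic arm can still matter: 1-benzofuran-5-yl in place of 4-hydroxy-3-methoxyphenyl gives a 1.4-fold higher number from compound 2 to compound 4 (0.15 log units; within the scatter) with no order to claim within the scatter, while 1-benzofuran-5-yl in place of 6-methoxypyridin-3-yl gives a 5.3-fold higher number from compound 1 to compound 4 (0.72 log units; beyond the scatter) and leaves the benzofuran compound the weaker inhibitor of that pair. No measurement at hand accounts for the loss that comes with the hydroxy.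

The compounds shown include no partner of compound 1 or compound 2 with hydrogen on this ring carbon, so whether the hydroxy brings a similar loss with those two arms remains open. Also open, going by these compounds, is how a methoxy, a fluorine or an amine at this same ring carbon would compare with hydroxy and with hydrogen.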